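The source may hold more compounds than are shown below. What is called first, only, known or untested is meant among the compounds shown, and "the series" means these compounds.

Compound 1 `COc1cc(-c2nn(-c3cccc(NC(=O)Nc4cc(C(F)(F)F)cc(C(F)(F)F)c4)c3)cc2-c2ccncc2)ccc1Cl` and compound 2 `O=C(Nc1cccc(-n2cc(-c3ccncc3)c(-c3ccc(Cl)c(O)c3)n2)c1)Nc1cc(C(F)(F)F)cc(C(F)(F)F)c1` share one core; compound 3 `COc1cc(-c2nn(-c3cccc(NC(=O)Nc4ccc(Cl)c(C(F)(F)F)c4)c3)cc2-c2ccncc2)ccc1Cl` and compound 4 `O=C(Nc1cccc(-n2cc(-c3ccncc3)c(-c3ccc(Cl)c(O)c3)n2)c1)Nc1ccc(Cl)c(C(F)(F)F)c1` share another. The difference between the two cores is not broken down here. In a functional assay on MDA-MB-231 cells (Homo sapiens) for inhibition, read by sulforhodamine B assay, with a stated time of 48 h (on this read-out lower numbers stand for higher toxicity in this test and higher numbers for lower toxicity in this test), compound 1 gives 3000 nM, and compound 2 gives 3720 nM. Compound 3 gives 13300 nM in this assay.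

Compound 2 arises from compound 1 by one change (hydrogen in place of methyl on an oxygen on an aromatic ring), and the same change leads from compound 3 to compound 4 (hydrogen in place of methyl on an oxygen on an aromatic ring). The measured step was a 1.2-fold higher number from compound 1 to compound 2 (0.09 log units; within the scatter).

Because that step stayed within the scatter, compound 4 is expected to stand close to compound 3 in this assay, with a step of about a 1.1-fold higher number from compound 3 to compound 4 (0.05 log units; within the scatter). The estimated value for compound 4 is 15000 nM, most likely between 7000 nM and 32000 nM.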

Compound 4, concentration lethal to 50% of the cells: 11400 nM
Compound 4: the middle estimate sits 1.3-fold (0.12 log units) above what was measured, and the stated range covers the measured number.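

On the core of compound 3, replacing methoxy with hydroxy gives a 1.2-fold lower number from compound 3 to compound 4 (0.07 log units; within the scatter) in this assay. Set side by side, the two steps agree, so in these two pairs the change carries over from one core to the other: the same change on two cores in this assay, a 1.2-fold higher number (0.09 log units; within the scatter) from compound 1 to compound 2 and a 1.2-fold lower number (0.07 log units; within the scatter) from compound 3 to compound 4, 1.4-fold (0.16 log units) apart, within the scatter of two such steps. Within the data shown here, this shows only that the change leaves no readable difference on either of these two cores in this one test; it does not show that the same would hold on a further core or in a different test.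

Still open, from the compounds shown here alone, is whether another group on that oxygen, such as an ethoxy or a longer chain, or an amine in place of the hydroxy, would give a step beyond the scatter on either core.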